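The source may hold more compounds than are shown below. What is called first, only, known or untested is meant among the compounds shown, and "the series" means these compounds.

Of the compounds shown here, three built on a shared core have been measured so far, and a fourth is waiting. In a functional assay on U-87MG ATCC cells for antiproliferative activity against U-87 MG (Homo sapiens), read by spectrophotometry, with a stated time of 2 days (a higher number here means a weaker inhibitor of growth, a lower number a stronger inhibitor of growth), compound 1 `COc1cc(Nc2ncc(C(F)(F)F)c(N3Cc4cccc(N(C)S(C)(=O)=O)c4C3)n2)c(OC)cc1Cl` gives 6200 nM, the lowest number of the three and thus the strongest growth inhibition among them. Compound 3 `CN(c1cccc2c1CN(c1nc(Nc3cc(C(F)(F)F)cc(C(F)(F)F)c3)ncc1C(F)(F)F)C2)S(C)(=O)=O` gives 16800 nM and compound 2 `CN(c1cccc2c1CN(c1nc(Nc3ccc(Nc4ccccc4)cc3)ncc1C(F)(F)F)C2)S(C)(=O)=O` gives 29800 nM, both higher than compound 1 by more than the usual scatter.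

The next molecule, compound 4 `CN(c1cccc2c1CN(c1nc(Nc3ccc(Cl)c(C(F)(F)F)c3)ncc1C(F)(F)F)C2)S(C)(=O)=O`, keeps the core of compound 1 and changes only the aryl group on the nitrogen: 4-chloro-3-(trifluoromethyl)phenyl in place of 4-chloro-2,5-dimethoxyphenyl on a nitrogen on an aromatic ring. Thus 4-chloro-3-(trifluoromethyl)phenyl replaces 4-chloro-2,5-dimethoxyphenyl. For the measured compounds named here, no measured pair shows this exact swap, so any forecast is rough. The closest guide is compound 3, which also has trifluoromethyl and no methoxy on that ring, and which gives 16800 nM. The chlorine of compound 1 stays in compound 4, so the number may not climb quite as far. A moderate rise in this assay is therefore expected, meaning somewhat weaker growth inhibition, and the estimated step is a 1.9-fold higher number from compound 1 to compound 4 (0.29 log units; within the scatter). The estimated value for compound 4 is 12000 nM, with an expected range from 5000 nM to 30000 nM.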

Compound 4, concentration for 50% growth inhibition: > 30000 nM
Compound 4 ended at the assay's limit; the forecaster's own chance of this, stated with the estimate: 12%; at least 2.5-fold (0.39 log units) between middle value and limit.
By their numbers in this assay, from the lowest: compound 1; then compounds 3 and 2 (each within the scatter of the next). At a limit, above all of these: compound 4.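

In this assay compound 4 gives > 30000 nM, which is a limit of the assay and not a number: the limit of > 30000 nM in this assay, at which 1 of the 4 values shown sits.

With the shared core unchanged, putting 4-chloro-3-(trifluoromethyl)phenyl in place of 4-chloro-2,5-dimethoxyphenyl on a nitrogen on an aromatic ring gives an at least 4.8-fold higher number from compound 1 to compound 4 (0.68 log units; beyond the scatter), so the group at this position clearly affects the read-out, and this is the only step shown for a single change there. The chlorine stands in both groups, so keeping it is not enough to preserve the growth inhibition seen with compound 1; what leaves is the pair of methoxy groups, and what enters is trifluoromethyl.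

This single swap does both things at once, so it cannot tell whether the weaker result follows the departure of the methoxy groups or the arrival of trifluoromethyl, and the limit leaves the full size of the step unknown. Also open, from the compounds shown here alone, is how growth inhibition would respond to an amine or a carboxylic acid in place of the trifluoromethyl group on this ring.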